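The compounds below may be only part of what the source reports. "The series", "measured", "known", "first", "only" and "open" are said of these compounds alone.

In a functional assay on HT-29 cells (Homo sapiens) for cytotoxicity, read by MTT assay, with a stated time of 24 h (a higher number here means a weaker inhibitor, a lower number a stronger inhibitor), compound 2 `CN1CCN(CC(=O)Nc2ccc(-c3nc(-c4ccccc4)c(-c4ccccc4)n3C)cc2)CC1` gives 35.5 ug/mL, the lowest of the two numbers recorded, though its nearest neighbour lies within the scatter: compound 1 `Cn1ccnc1SCC(=O)Nc1ccc(-c2nc(-c3ccccc3)c(-c3ccccc3)n2C)cc1` gives 47.5 ug/mL. Among the measured compounds shown here, the only measured step, a 1.3-fold lower number from compound 1 to compound 2 (0.13 log units; within the scatter), exchanges the whole group on the saturated chain carbon bound to the carbonyl carbon and does not separate the two compounds.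

Compound 3 `CCN1CCN(CC(=O)Nc2ccc(-c3nc(-c4ccccc4)c(-c4ccccc4)n3C)cc2)CC1` differs from compound 2 by methyl in place of hydrogen on a saturated chain carbon bound to an amine nitrogen in a ring. For the measured compounds named here, no measured step touches the saturated chain carbon bound to the amine nitrogen in the ring; the step from compound 1 to compound 2 is the sole comparison available, it sits within the scatter, and it concerns a different place, so it bears on the present change only by showing that a change in this region has so far not moved the number beyond the scatter. On that basis the estimated step is a 1.0-fold lower number from compound 2 to compound 3 (0.01 log units; within the scatter), expected to be none beyond the scatter in either direction. Compound 3 is therefore estimated at 35 ug/mL in this assay, with an expected range from 17 ug/mL to 70 ug/mL.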

Compound 3, half-maximal inhibitory concentration: 75 ug/mL
Compound 3: the middle estimate sits 2.1-fold (0.33 log units) below what was measured, and the stated range ends below it.
By their numbers in this assay, from the lowest: compounds 2, 1 and 3 (each within the scatter of the next, the first and the last beyond it).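

In this assay, among the compounds shown here, this position gives the first step beyond the scatter: a 2.1-fold higher number from compound 2 to compound 3 (0.32 log units; beyond the scatter), with methyl in place of hydrogen on a saturated chain carbon bound to an amine nitrogen in a ring, which turns 4-methylpiperazin-1-yl into 4-ethylpiperazin-1-yl. The change is modest and adds a single carbon, yet it separates two compounds, whereas exchanging the entire group in the step from compound 1 to compound 2 did not, so the number is sensitive to a small change at this place and moves toward a weaker inhibitor. The exchange of (1-methyl-1H-imidazol-2-yl)sulfanyl for 4-ethylpiperazin-1-yl, a 1.6-fold higher number from compound 1 to compound 3 (0.20 log units; within the scatter), stays within the scatter, leaving compound 1 unseparated from either piperazine compound, and nothing available accounts for the effect of the added methyl.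

From the compounds shown here alone, whether a longer chain, as in 4-propylpiperazin-1-yl, would carry the number further in the same direction remains open, and a single step cannot show a trend. Also open, going by these compounds, is how piperazin-1-yl, carrying hydrogen in place of the alkyl group, or morpholin-4-yl would compare with compound 2.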